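The compounds below may be only part of what the source reports. "The series", "measured", "known", "first", "only" and "open" are said of these compounds alone.

Measured so far in a functional assay (plasma) for inhibition, with Homo sapiens as the target; a higher number here means a weaker inhibitor, a lower number a stronger inhibitor:
- compound 1 `CCCCC[C@H](O)CCC1C(=O)C[C@H](O)[C@@H]1CCCCCCC(=O)O` gives 3.2 ug/mL
- compound 2 `CCCCC[C@H](O)C/C=C1/C(=O)C[C@H](O)[C@@H]1C/C=C\CCCC(=O)O` gives 0.1 ug/mL

Compound 2 at 0.1 ug/mL has the lower of the two numbers and is the stronger inhibitor. Compound 1 at 3.2 ug/mL stands above it, beyond the scatter.

Compound 3 `CCCCC/C=C/C=C1/C(=O)C[C@H](O)[C@@H]1C/C=C\CCCC(=O)O` carries hept-1-en-1-yl in place of 2-hydroxyheptyl on a double-bonded chain carbon bound to a double-bonded ring carbon. For the measured compounds named here, no measured pair isolates this change, so its size is a judgement with wide margins. The estimated change is upward, toward weaker inhibition and beyond the scatter, with a 20-fold higher number from compound 2 to compound 3 (1.30 log units; beyond the scatter) as the expected size. Compound 3 is expected at 2 ug/mL within an estimated range of 0.3 ug/mL to 12 ug/mL in the coming measurement.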

Compound 3, half-maximal inhibitory concentration: 0.32 ug/mL
Compound 3: middle estimate off by 6.3-fold (0.80 log units), on the high side; measured number inside the range.
By their numbers in this assay, from the lowest: compound 2; then compound 3; then compound 1.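

In this assay, hept-1-en-1-yl in place of 2-hydroxyheptyl on a double-bonded chain carbon bound to a double-bonded ring carbon gives a modest weakening (a 3.2-fold higher number from compound 2 to compound 3 (0.51 log units; beyond the scatter)). This position therefore accepts a chain without the hydroxy group and without the defined stereocentre, and inhibition persists, with compound 3 at 0.32 ug/mL. The swap changes these features and adds a double bond all at once, and no supporting data bear on the origin of the step.

Still open, on these data alone, is how much of the step belongs to the hydroxy group and how much to the double bond; a saturated heptyl chain or a 2-aminoheptyl chain at this place would help separate them. Also open, as far as these compounds go, is how a longer chain would read here.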